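A few compounds are considered here, and "the series" means these few. Any claim that something is new, unique, unknown or untested is made for them only; others in the source may bear on it.

In a functional assay on H80 cells (Homo sapiens) for cytotoxicity, read by trypan blue exclusion, with a stated time of 96 h (a higher number here means a weaker inhibitor of growth, a lower number a stronger inhibitor of growth), compound 1 `COc1ccc(NS(=O)(=O)/C=C/c2c(OC)cc(OC)cc2OC)cc1` gives 100 nM, and compound 2 `COc1cc(OC)c(/C=C/S(=O)(=O)Nc2ccc(OC)c(O)c2)c(OC)c1` gives 25 nM. The change between them, hydroxy in place of hydrogen on an aromatic carbon, produced a 4.0-fold lower number from compound 1 to compound 2 (0.60 log units; beyond the scatter), so compound 2 stands lowest of the two numbers measured. Compound 3 `COc1cc(OC)c(/C=C/S(=O)(=O)Nc2ccc(OC)c(N)c2)c(OC)c1` differs from compound 2 by amino in place of hydroxy on an aromatic carbon. Among the measured compounds shown here, no measured pair swaps amino for hydroxy; the only step known, from compound 1 to compound 2, shows that a small group at this carbon can move the number modestly. Compound 3 is therefore expected to land near compound 2, with a step of a 2.0-fold higher number from compound 2 to compound 3 (0.30 log units; within the scatter) and an estimate of 50 nM, between 15 nM and 160 nM.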

Compound 3, concentration for 50% growth inhibition: 4 nM
Estimate against measurement, compound 3: 13-fold (1.10 log units) above, and the stated range ends above it.
By their numbers in this assay, from the lowest: compound 3; then compound 2; then compound 1.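

In this assay, this carbon responds to which group it carries, not only to whether it carries one. Hydroxy and amino each count as one heavy atom with the same tally of hydrogen-bond donors and acceptors, yet the swap still moves the number (a 6.3-fold lower number from compound 2 to compound 3 (0.80 log units; beyond the scatter)). Against hydrogen at this carbon, amino gives a larger step (a 25-fold lower number from compound 1 to compound 3 (1.40 log units; beyond the scatter)) than hydroxy does (a 4.0-fold lower number from compound 1 to compound 2 (0.60 log units; beyond the scatter)). Nothing available accounts for this difference.
The compounds shown leave open whether a methylamino, dimethylamino or acetamido group at this carbon would keep the number this low.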